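This account rests on a few compounds, and the source may have more. Where it says the series, first, only, none or still open, it means among the compounds named here.

Compound 1 `CCn1nc(C)cc1C(=O)Nc1nc2cc(C(N)=O)cc(OC)c2n1CCCNC(=O)OCc1ccccc1` gives only a limit in an assay for activation of interferon regulatory factor 3 (Homo sapiens), read by a luciferase reporter, with a stated time of 20 h (on this read-out higher numbers stand for an effect only at larger amounts of compound and lower numbers for an effect already at smaller amounts), namely > 100000 nM.
Compound 2 `COc1cc(C(N)=O)cc2nc(NC(=O)c3nccc4ccccc34)n(CCCNC(=O)OCc3ccccc3)c12` gives only a limit in this assay, namely > 100000 nM.
Compound 3 `COc1cc(C(N)=O)cc2nc(NC(=O)c3cncn3C)n(CCCNC(=O)OCc3ccccc3)c12` gives only a limit in this assay, namely > 100000 nM.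

Compound 3 therefore stands at the limit of this assay, and it stands there together with the other two members of the set, since (the limit of > 100000 nM in this assay, at which 3 of the 3 values shown sit). None of the three pairs yields a readable step: the change from compound 1 to compound 2 is a step that the two limits leave unreadable from compound 1 to compound 2, that from compound 1 to compound 3 is a step that the two limits leave unreadable from compound 1 to compound 3, and that from compound 2 to compound 3 is a step that the two limits leave unreadable from compound 2 to compound 3. Exchanging one aromatic carboxamide for another on the carbonyl carbon has so far left every compound at the limit.

Compound 4 `COc1cc(C(N)=O)cc2nc(NC(=O)c3cccn3C)n(CCCNC(=O)OCc3ccccc3)c12` differs from compound 3 only in this: 1-methyl-1H-pyrrol-2-yl in place of 1-methyl-1H-imidazol-5-yl on a carbonyl carbon. Going by the values given here, no measured step bears on this exchange, and the three values at hand give no direction, since all of them are limits. The expectation for compound 4 in this assay is accordingly that the step from compound 3 to compound 4, estimated as a number no higher from compound 3 to compound 4 (the limit leaves the size open), stays within the scatter and that compound 4 most likely remains at the limit. The estimate for compound 4 is 100000 nM, with a range from 30000 nM to 300000 nM.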

Compound 4, half-maximal effective concentration: > 100000 nM
Compound 4 was reported as a limit; the forecaster's own chance of this, stated with the estimate: 85%; the middle value sits exactly at the limit.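

Compound 4 is reported only as a limit in this assay, as are compound 1, compound 2 and compound 3, so none of the steps among them can be read: (the limit of > 100000 nM in this assay, at which 4 of the 4 values shown sit). The compounds shown leave open whether any group on the carbonyl carbon gives a measurable effect in this assay, and how these four compounds would rank.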